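The stereoisomer of compound 2 in the peroxide acid series

The source may hold more compounds than are shown below. What is called first, only, known or untested is meant among the compounds shown, and "the series" means these compounds.

In a functional assay on HT-29 cells (Homo sapiens) for inhibition (on this read-out higher numbers stand for weaker inhibition of growth and lower numbers for stronger inhibition of growth), three compounds of a shared peroxide-acid core have been measured. Compound 3 `C=C1CCC[C@H]2[C@](C)(CC[C@]3(C)CC[C@H]([C@@H](C)C(=O)O)OO3)[C@@H](C)CC[C@]12C` gives 1570 nM. Compound 1 `C=C1CCCC(C)(C)C1CC[C@]1(C)CC[C@@H]([C@@H](C)C(=O)O)OO1` returns only a limit of the assay, > 10000 nM, as recorded in the limit of > 10000 nM in this assay, at which 1 of the 3 values shown sits. Compound 2 `CC1=C(CC/C(C)=C/CC[C@@]2(C)CC[C@@H]([C@H](C)C(=O)O)OO2)C(C)(C)CCC1` also returns only a limit, > 100000 nM; this stands as the limit of > 100000 nM in this assay, at which 1 of the 3 values shown sits, and so compound 2 has no number of its own against which the other values can be ranked. Compound 4 `CC1=C(CC/C(C)=C/CC[C@@]2(C)CC[C@H]([C@H](C)C(=O)O)OO2)C(C)(C)CCC1` has the same atoms and bonds as compound 2 and differs only in configuration as drawn: the two compounds have the same atoms and bonds and differ only in configuration as drawn: 1 of 4 stereo elements differ; a stereocentre at a saturated ring carbon is drawn S in compound 2 and R in compound 4. No measured pair in this set differs in a single place, so no step of this kind has been observed, and the data give no cause to expect the inversion of one stereocentre to move the value out of the scatter. Compound 4 is therefore expected to give 100000 nM, within 30000 nM to 300000 nM, most probably again as a limit rather than a number. The expected step of a number no higher from compound 2 to compound 4 (the limit leaves the size open) is none beyond the scatter.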

Compound 4, concentration for 50% growth inhibition: > 5000 nM
Compound 4: a limit, no number; the forecaster's own chance of this, stated with the estimate: 70%; the middle value lies beyond the limit too.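

Compound 2 and compound 4 both stand only as limits in this assay, so no step can be read between them. The compounds shown leave open whether inverting this single stereocentre changes growth inhibition at all, and in which direction.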